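The compounds below may be only part of what the source reports. "The series", "measured", "known", "first", "only" and "open" are said of these compounds alone.

Measured in a functional assay on THP-1 cells (Homo sapiens) for cytotoxicity, read by MTT assay, with a stated time of 24 h; on this read-out higher numbers stand for weaker inhibition and lower numbers for stronger inhibition:
- compound 1 `COc1cc(/C=C2\CN(C)C/C(=C\c3ccccc3F)C2=O)cc(OC)c1`: 1170 nM
- compound 2 `COc1cc(/C=C2\CN(C)C/C(=C\c3ccccc3F)C2=O)cc(OC)c1OC`: 640 nM
- compound 3 `CN1C/C(=C\c2cccc([N+](=O)[O-])c2)C(=O)/C(=C/c2ccccc2F)C1`: 1010 nM

These three values lie within the usual scatter of one another, so compound 1 stands level with compound 2 and compound 3. Compound 4 `COc1cc(/C=C2\CN(C)C/C(=C\c3ccc(Cl)cc3Cl)C2=O)cc(OC)c1` differs from compound 1 as follows: 2,4-dichlorophenyl in place of 2-fluorophenyl on a double-bonded chain carbon bound to a double-bonded ring carbon. In words, this is 2,4-dichlorophenyl in place of 2-fluorophenyl on a double-bonded chain carbon bound to a double-bonded ring carbon. Among the compounds with values here, the one measured step, a 1.8-fold lower number from compound 1 to compound 2 (0.26 log units; within the scatter), is methoxy in place of hydrogen on an aromatic carbon and leaves the 2-fluorophenyl untouched. Within the data shown here, no measured step changes that group, so no shift beyond the scatter is expected. The estimate corresponds to an expected 1.3-fold lower number from compound 1 to compound 4 (0.11 log units; within the scatter). For compound 4 the expected value is 900 nM. The estimated range for compound 4 runs from 350 nM to 2300 nM.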

Compound 4, half-maximal inhibitory concentration: 6070 nM
The estimate for compound 4 lay 6.7-fold (0.83 log units) below the measured number; the measured number lies above the stated range.
By their numbers in this assay, from the lowest: compounds 2, 3 and 1 (each within the scatter of the next); then compound 4.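

At this position, on a double-bonded chain carbon bound to a double-bonded ring carbon, the aryl group matters in this assay: 2,4-dichlorophenyl in place of 2-fluorophenyl gives a 5.2-fold higher number from compound 1 to compound 4 (0.72 log units; beyond the scatter) and so weakens inhibition. Compounds 1, 2 and 3 all carry the 2-fluorophenyl there, so they could not show this. No evidence at hand accounts for the shift.

The compounds shown leave open whether 2-chlorophenyl or 4-chlorophenyl alone would give a similar step. From the compounds shown here alone, how plain phenyl or a pyridyl group would fare at this position also remains open.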